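This account rests on a few compounds, and the source may have more. Where it says the series, first, only, none or still open, it means among the compounds named here.

Measured in an in vitro assay on HEK385-7 cells for displacement of a labelled ligand from prostaglandin D2 receptor 2 (Homo sapiens); on this read-out lower numbers stand for stronger inhibition and higher numbers for weaker inhibition:

Compound 1, `N#Cc1cc(-c2nc(C(c3ccc(F)cc3)c3ccc(F)cc3)sc2CC(=O)O)ccc1F`, gives 57 nM.
Compound 2, `O=C(O)Cc1sc(C(c2ccc(F)cc2)c2ccc(F)cc2)nc1-c1cn[nH]c1`, gives 16 nM.

Compound 2 stands with the lowest number of the two, and its nearest neighbour is compound 1, which differs only in the group on the shared core. That single step, a 3.6-fold lower number from compound 1 to compound 2 (0.55 log units; beyond the scatter), is the only one measured so far.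

Compound 3, `O=C(O)Cc1sc(C(c2ccc(F)cc2)c2ccc(F)cc2)nc1-c1ccnc(F)c1`, is not yet measured. It differs from compound 2 by 2-fluoropyridin-4-yl in place of 1H-pyrazol-4-yl on an aromatic carbon.

Going by the values given here, only one measured step touches this position, and it runs the other way: a six-membered ring gave way to the five-membered pyrazole in a 3.6-fold lower number from compound 1 to compound 2 (0.55 log units; beyond the scatter). Compound 3 brings back a six-membered ring, though a different one from that of compound 1, with one hetero atom and no hydrogen-bond donor. Some loss against compound 2 is therefore expected, but not necessarily the whole way back to compound 1, so the expected step is a 2.2-fold higher number from compound 2 to compound 3 (0.34 log units; beyond the scatter) in this assay.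

For compound 3 the estimate in this assay is 35 nM, with a range from 12 nM to 100 nM.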

Compound 3, half-maximal inhibitory concentration: 0.48 nM
Compound 3: the middle estimate sits 73-fold (1.86 log units) above what was measured; measured number outside the range, below it.
By their numbers in this assay, from the lowest: compound 3; then compound 2; then compound 1.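

In this assay, the move to 2-fluoropyridin-4-yl gives a 33-fold lower number from compound 2 to compound 3 (1.52 log units; beyond the scatter) and so reverses the expectation drawn from the earlier pair: at this position, a six-membered aromatic ring with no hydrogen-bond donor can far outdo the 1H-pyrazol-4-yl group, so that group's donor is not required for a low number. Ring size alone does not set the level either, since the 3-cyano-4-fluorophenyl group also has a six-membered ring, yet replacing it gives a 120-fold lower number from compound 1 to compound 3 (2.07 log units; beyond the scatter) and the sequence runs from that group through the pyrazole to the fluoropyridine. Nothing available here accounts for steps of this size.

With the ring nitrogen and the fluorine entering together, these compounds do not show how much of the gain belongs to each of them, a question that plain pyridin-4-yl and phenyl groups at this position could separate. Going by these compounds, it also remains open whether the fluorine itself matters or whether another small group in its place, such as a chlorine, a methoxy group or an amine, would give a similar number.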